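Trading the methoxyphenyl arm for a saturated ring

The source may hold more compounds than are shown below. What is called first, only, known or untested is meant among the compounds shown, and "the series" means these compounds.

Compound 1 `COc1ccc(Cn2ccc3nc(-c4ccccc4)nc-3c2)cc1` is tested in an ADME assay on MDBK cells (Bos taurus) for cytotoxicity (a higher number here means that more compound is tolerated, a lower number that less compound is tolerated), and gives > 100000 nM, which is a limit of the assay rather than a number. Among the compounds with values here, it is the one compound that sits at the limit of > 100000 nM in this assay, at which 1 of the 3 values shown sits, so its true position is known only as a range. Compound 2 `FC(F)(F)c1ccc(Cn2ccc3nc(-c4ccccc4)nc-3c2)cc1` gives 84000 nM in this assay, and compound 3 `CC(C)(C)c1ccc(Cn2ccc3nc(-c4ccccc4)nc-3c2)cc1` gives 22000 nM. The measured changes are all at the same aromatic carbon: an at least 1.1-fold lower number from compound 1 to compound 2 (0.07 log units; that floor lies within the scatter), an at least 4.5-fold lower number from compound 1 to compound 3 (0.65 log units; beyond the scatter) and a 3.8-fold lower number from compound 2 to compound 3 (0.58 log units; beyond the scatter).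

Compound 4 `c1ccc(-c2nc3ccn(CC4CCCCC4)cc-3n2)cc1` differs from compound 1 by cyclohexyl in place of 4-methoxyphenyl on a saturated chain carbon bound to an aromatic nitrogen. Within the data shown here, no measured step exchanges the whole aromatic ring for a six-membered non-aromatic ring of carbon only, so none bears on it directly. The nearest guidance is compound 3, where a tert-butyl group of carbon only brought an at least 4.5-fold lower number from compound 1 to compound 3 (0.65 log units; beyond the scatter), while the trifluoromethyl of compound 2 brought only an at least 1.1-fold lower number from compound 1 to compound 2 (0.07 log units; that floor lies within the scatter). A group made of carbon only is therefore expected to push the number down in this assay, likely more than the trifluoromethyl did, and compound 4 is expected to show an at least 2.5-fold lower number from compound 1 to compound 4 (0.39 log units; beyond the scatter). Compound 4 is estimated at 40000 nM, with a range from 12000 nM to 130000 nM.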

Compound 4, half-maximal cytotoxic concentration: > 100000 nM
Compound 4: a limit, no number (the forecaster's own chance of this, stated with the estimate: 30%); at least 2.5-fold (0.39 log units) between middle value and limit.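

In this assay compound 4 gives > 100000 nM as a limit of the assay and not a number. Within the data shown here, compound 1 also stands at a limit, so no step between compound 1 and compound 4 can be read: the limit of > 100000 nM in this assay, at which 2 of the 4 values shown sit.

The compounds shown leave open how much of either compound is tolerated, and so whether cyclohexyl and 4-methoxyphenyl differ at all here.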